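A few compounds are considered here, and "the series" means these few. Any claim that something is new, unique, unknown or untested is made for them only; others in the source may bear on it.

In a functional assay on MCF7 cells (Homo sapiens) for inhibition, read by MTT assay, with a stated time of 24 h (a higher number here means a weaker inhibitor of growth, a lower number a stronger inhibitor of growth), compound 2 `COc1ccc(C(=O)n2c(-c3cn(C)c4ccc(OC)cc34)nc3ccccc32)cc1` gives 14800 nM, level with compound 1 `COc1cccc(C(=O)n2c(-c3cn(C)c4ccc(OC)cc34)nc3ccccc32)c1` at 14600 nM, while compound 3 `COc1ccc2c(c1)c(-c1nc3ccccc3n1C(=O)c1ccc(OC)c(OC)c1)cn2C` reads 6300 nM. Compound 4 `COc1ccc(C(=O)n2c(-c3cn(C)c4ccc(Br)cc34)nc3ccccc32)cc1` differs from compound 2 in one place: bromo in place of methoxy on an aromatic carbon. Among the compounds with values here, no measured compound shows a change at that place. The nearest evidence lies elsewhere in the molecule: moving a methoxy gave a 1.0-fold higher number from compound 1 to compound 2 (0.01 log units; within the scatter), and adding a methoxy gave a 2.3-fold lower number from compound 2 to compound 3 (0.37 log units; beyond the scatter). These steps give only a rough guide to size and no direction, so no change beyond the scatter is expected. The estimated step is a 1.2-fold lower number from compound 2 to compound 4 (0.09 log units; within the scatter). Compound 4 is expected at 12000 nM, with an estimated range from 4000 nM to 30000 nM.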

Compound 4, concentration for 50% growth inhibition: 19200 nM
Compound 4: middle estimate off by 1.6-fold (0.20 log units), on the low side; the range from low to high includes it.
By their numbers in this assay, from the lowest: compound 3; then compounds 1, 2 and 4 (each within the scatter of the next).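

This is the only change shown at this aromatic carbon of the fused ring system: in this assay, bromo in place of methoxy gives a 1.3-fold higher number from compound 2 to compound 4 (0.11 log units; within the scatter) and so leaves the reading within the usual scatter. At this level of growth inhibition, the methoxy at this place can therefore be exchanged for bromo without a measurable loss. No measurement here accounts for the two groups reading alike.

Going by these compounds, whether an amine, a carboxylic acid or a longer chain at this place would move the number remains open. So does whether bromo would read the same on the more methoxylated compound 3.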